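This account rests on a few compounds, and the source may have more. Where it says the series, first, only, none or still open, it means among the compounds named here.

Measured compounds:
- Compound 1 `O=C(N/N=C/c1ccc(Cl)cc1)c1cnccn1`: in an ADME assay on Vero cells (Chlorocebus sabaeus) for cytotoxicity, with a stated time of 72 h (a lower number here means that less compound is tolerated, a higher number that more compound is tolerated), compound 1 gives > 30 ug/mL, which is a limit of the assay rather than a number.
- Compound 2 `O=C(N/N=C/c1ccc(O)cc1)c1cnccn1`: in this assay compound 2 gives > 30 ug/mL, again a limit of the assay and not a number.

Within the data shown here, compound 2 therefore stands only at a limit, with no exact figure known for it, and the one other value shown is a limit as well. Both values sit at the limit of > 30 ug/mL in this assay, at which 2 of the 2 values shown sit. Among the measured compounds shown here, the single measured step between them, a step that the two limits leave unreadable from compound 1 to compound 2, cannot be read because the limit of > 30 ug/mL in this assay, at which 2 of the 2 values shown sit, hides whatever difference there may be.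

The unmeasured compound 3 `COc1ccc(/C=N/NC(=O)c2cnccn2)cc1` differs from compound 2 by methyl in place of hydrogen on an oxygen on an aromatic ring. For the measured compounds named here, no measured step bears on this change directly, and the only step that is known at all is unreadable, so there is nothing to give the size or direction of the step from compound 2 to compound 3. With both measured compounds at a limit, the most that can be said is that compound 3 is expected to show no step beyond the scatter, a step that the limit leaves unreadable from compound 2 to compound 3, and to sit at or near that limit as well. Compound 3 is therefore estimated at 50 ug/mL in this assay, in a range from 20 ug/mL to 150 ug/mL, and most likely the assay will again report only a limit.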

Compound 3, half-maximal cytotoxic concentration: > 30 ug/mL
Compound 3 ended at the assay's limit (the forecaster's own chance of this, stated with the estimate: 85%); the middle value is on the limit's open side.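

Neither step to compound 3, from compound 2 or from compound 1, can be read, because each value is a limit of the assay and not a number: the limit of > 30 ug/mL in this assay, at which 3 of the 3 values shown sit. The compounds shown leave open how much of each one the cells tolerate in this assay, and whether chloro, hydroxy or methoxy makes any difference there.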